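The compounds below may be only part of what the source reports. "The series", "measured", "known", "first", "only" and "open" are said of these compounds alone.

Of the compounds shown here, two with a shared core have been measured so far. Compound 1 `Cc1c(OCCCCOCOc2ccc(C(=O)O)cc2)ccc(C(=O)CC2CCCC2)c1O` gives 46.9% in an assay on HEK293 cells for positive allosteric modulation of metabotropic glutamate receptor 3 (Rattus norvegicus), read by thallium flux, with a stated time of 2.5 min (on this read-out lower numbers stand for smaller maximal responses and higher numbers for larger maximal responses), and compound 2 `Cc1c(OCCCCOc2ccc(C(=O)O)cc2)ccc(C(=O)CC(C)C)c1O` gives 51.9% in this assay. Of these two numbers, compound 1 stands at the lower one, and its nearest neighbour, compound 2, lies only a few points higher, a gap that falls within the usual scatter of this kind of measurement; the two values therefore cannot be told apart with confidence.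

The next compound to be measured is compound 3 `Cc1c(OCCCCOc2ccc(C(=O)O)c(Cl)c2)ccc(C(=O)CC2CCCC2)c1O`. It differs from compound 1 in a single place: 4-carboxy-3-chlorophenyl in place of (4-carboxyphenoxy)methyl on an oxygen on a saturated carbon. Among the measured compounds shown here, no measured step between two compounds covers a change of this kind, so the size of the effect is open. The expected step from compound 1 to compound 3 is small, a number 8.1 percentage points higher from compound 1 to compound 3 (within the scatter), and is not expected to exceed the scatter in either direction. On that basis, compound 3 is expected to show about 55% in this assay, with a likely range from 35% to 75%.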

Compound 3, largest response reached (reported as percent of maximum), in percent of the reference or control that the assay uses: 40%
Beside the measured number, compound 3's estimate is 15 percentage points above it; the range from low to high includes it.
By their numbers in this assay, from the lowest: compounds 3, 1 and 2 (each within the scatter of the next, the first and the last beyond it).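

In this assay, among the compounds shown here, replacing (4-carboxyphenoxy)methyl with 4-carboxy-3-chlorophenyl on an oxygen on a saturated carbon gives the first readable step at this place: a number 6.9 percentage points lower from compound 1 to compound 3 (within the scatter). The maximal response therefore cannot be told apart across this change, even though the entering group holds a chlorine and the leaving group holds an additional oxygen. That is the limit of the reading, since this single step alters both features together and cannot separate the contribution of one from the other, and no supporting data bear on the result.

As far as these compounds go, what remains open is whether the chlorine and the shorter link would each leave the response equally unchanged if taken alone, or whether they have opposing effects that happen to cancel in this pair. From the compounds shown here alone, it is also open whether a fluorine or a nitrile in place of the chlorine, or a tetrazole in place of the carboxylic acid, would move the response beyond the usual scatter of this measurement.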